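This account rests on a few compounds, and the source may have more. Where it says the series, first, only, none or still open, it means among the compounds named here.

Working notes on the series. Three compounds share one core: compound 1 `Cc1ccc(/C=C2\SC(=O)N(Cc3ccc(C)cc3)C2=O)cc1`, compound 2 `COc1ccc(/C=C2\SC(=O)N(Cc3ccc(C)cc3)C2=O)cc1` and compound 3 `Cc1ccc(CN2C(=O)S/C(=C\c3ccc(O)cc3)C2=O)cc1`. In a functional assay on the whole organism (plasma) with Mus musculus as the target, with a stated time of 15 days, at a dose of 10 mg/kg by the oral route (on this read-out higher numbers stand for a stronger effect at the one dose given and lower numbers for a weaker effect), compound 1 gives 16.3%, compound 2 gives 20.6% and compound 3 gives 19.9%, the second highest of the three; the nearest number belongs to compound 2 and the furthest to compound 1. Both spreads are small: a number 0.7 percentage points lower from compound 2 to compound 3 (within the scatter), and a number 3.6 percentage points higher from compound 1 to compound 3 (within the scatter). Compound 4 `Cc1ccc(CN2C(=O)S/C(=C\c3ccc(Cl)cc3)C2=O)cc1` is not yet measured. Its change from compound 3 is chloro in place of hydroxy on an aromatic carbon. Within the data shown here, no measured step exchanges hydroxy for chloro; the steps that alter this position, a number 4.3 percentage points higher from compound 1 to compound 2 (within the scatter) and a number 3.6 percentage points higher from compound 1 to compound 3 (within the scatter), both lie within the scatter, so no step beyond the scatter is expected in this assay, that is a number 0.9 percentage points lower from compound 3 to compound 4 (within the scatter). Compound 4 is therefore estimated at 19%, between 9% and 29%.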

Compound 4, a percentage reported as activity, at one dose (the size of the read-out at that dose, not a potency): 18.7%
The estimate for compound 4 lay 0.3 percentage points above the measured number, within the range that was stated.
By their numbers in this assay, from the lowest: compounds 1, 4, 3 and 2 (each within the scatter of the next).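

Chloro now joins methyl, methoxy and hydroxy on this aromatic carbon, para to a large group, and in this assay each exchange stays within the scatter (a number 1.2 percentage points lower from compound 3 to compound 4 (within the scatter); a number 1.9 percentage points lower from compound 2 to compound 4 (within the scatter); a number 2.4 percentage points higher from compound 1 to compound 4 (within the scatter)). Replacing hydroxy, with its hydrogen-bond donor and acceptor, by chloro, with neither, therefore gives no step beyond the scatter. No supporting measurement explains these numbers.

The compounds shown leave open whether an amine or a carboxylic acid at this position would give a step beyond the scatter. They also leave open whether changes elsewhere on the shared core would do so.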